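The source may report more compounds than this note shows. Statements on the series, on what has been measured and on what is new or still open speak of the compounds shown alone.

Values so far in a physicochemical assay for lipophilicity, read by LC-MS, using the shake flask method, in phosphate buffer, measured as octanol-water partition, with a stated time of 2 h, at pH 7.4; on this read-out higher numbers stand for higher lipophilicity and lower numbers for lower lipophilicity:

- compound 1 `O=C(O)c1cccc(-n2cc(CO[C@H]3O[C@H](CO)[C@@H](O)[C@H](O)[C@@H]3O)nn2)c1` gives "not determined" (no result reported)
- compound 2 `O=C(O)c1cncc(-n2cc(CO[C@H]3O[C@H](CO)[C@@H](O)[C@H](O)[C@@H]3O)nn2)c1` gives "not determined" (no result reported)
- compound 3 `COc1ccc(Cn2cc(CO[C@H]3O[C@H](CO)[C@@H](O)[C@H](O)[C@@H]3O)nn2)cc1` gives -0.4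

For the measured compounds named here, compound 2 therefore has no number of its own to stand on, and compound 1 shares that gap, so compound 3 holds the only reading available. The next compound to be tested is compound 4 `OC[C@H]1O[C@H](OCc2cn(-c3ccc(F)cc3)nn2)[C@@H](O)[C@@H](O)[C@@H]1O` and it has yet to be measured. The structural change is 4-fluorophenyl in place of 5-carboxypyridin-3-yl on an aromatic nitrogen and it puts 4-fluorophenyl in place of 5-carboxypyridin-3-yl on an aromatic nitrogen. Without a starting number, the size of this step cannot be read from the data. A step upward in this assay is still expected, toward higher numbers and beyond the usual scatter of repeated measurements. The only anchor for the estimate is compound 3 at -0.4 and compound 4 is expected to land close to that reading. In this assay the expected value for compound 4 is estimated at -0.2 with a likely range from -0.7 to 0.3.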

Compound 4, distribution coefficient: -0.15
Compound 4: the middle estimate sits 0.05 log units below what was measured; low and high end bracket the measured number.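

In this assay, putting 4-fluorophenyl in place of 4-methoxybenzyl on the aromatic nitrogen gives a number 0.25 log units higher from compound 3 to compound 4 (within the scatter), so this position has now accepted two quite different groups whose readings cannot be told apart. For the compounds shown here, compound 1 and compound 2 have no number, so no step from either of them can be read, and the effect of leaving 5-carboxypyridin-3-yl remains unknown. Nothing at hand explains the result.

Still open, from the compounds shown here alone, is whether the fluorine and the methoxy group, or the presence and absence of the benzyl carbon, each matter on their own, since this single swap changes both and a small net step could hide separate shifts. Also open, going by these compounds, is what a 2-phenylethyl group, with its longer chain, or a 4-aminophenyl group would read at this position.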